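One carbon less on the hydroxy-tipped chain

The source may report more compounds than this note shows. Statements on the series, on what has been measured and on what is new or still open speak of the compounds shown alone.

Three compounds have so far been measured in a functional assay, read by fluorescence and spectrophotometry, with a stated time of 1 h; on this read-out higher numbers stand for an effect only at larger amounts of compound and lower numbers for an effect already at smaller amounts:

compound 1, `CCCCCCCS(=O)(=O)/C=C/c1ccc(O)c(O)c1`, giving 7100 nM
compound 2, `CCCCCCCCS(=O)(=O)/C=C/c1ccc(O)c(O)c1`, giving 6400 nM
compound 3, `O=S(=O)(/C=C/c1ccc(O)c(O)c1)CCCCCCCCO`, giving 6700 nM

Compound 3 stands second highest of the three numbers, but every gap separating it from compound 1 and compound 2 is within the scatter, so the three are not told apart. Compound 4, `O=S(=O)(/C=C/c1ccc(O)c(O)c1)CCCCCCCO`, is not yet measured in this assay. It differs from compound 3 in one place: hydroxy in place of hydroxymethyl on a saturated chain carbon, seven bonds along the chain from a sulfonyl sulfur. The measured steps that bear on this are changes at the same stretch of chain: a 1.1-fold lower number from compound 1 to compound 3 (0.03 log units; within the scatter) and a 1.0-fold higher number from compound 2 to compound 3 (0.02 log units; within the scatter), with a 1.1-fold lower number from compound 1 to compound 2 (0.05 log units; within the scatter) showing the same for a bare chain extension. All three lie within the scatter, so removing one carbon from the hydroxylated chain is expected to move nothing beyond the scatter either, with an estimated step of a 1.0-fold higher number from compound 3 to compound 4 (0.01 log units; within the scatter). Compound 4 is therefore expected to give about 6800 nM, within a range from 3400 nM to 13600 nM.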

Compound 4, half-maximal effective concentration: 5900 nM
Compound 4: the middle estimate sits 1.2-fold (0.06 log units) above what was measured, within the range that was stated.
By their numbers in this assay, from the lowest: compounds 4, 2, 3 and 1 (each within the scatter of the next).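

In this assay, among these compounds, compound 4 gives the first reading of hydroxy in place of hydroxymethyl on a saturated chain carbon, seven bonds along the chain from a sulfonyl sulfur, and that exchange stays small: a 1.1-fold lower number from compound 3 to compound 4 (0.06 log units; within the scatter). The steps to the two compounds without hydroxy are no larger, a 1.1-fold lower number from compound 2 to compound 4 (0.04 log units; within the scatter) and a 1.2-fold lower number from compound 1 to compound 4 (0.08 log units; within the scatter), so none of the four compounds is told apart from another on these steps. Hydroxy in place of hydrogen can now be read on two cores, where the earlier compounds gave only one case, and the two readings agree: the same change on two cores in this assay, a 1.0-fold higher number (0.02 log units; within the scatter) from compound 2 to compound 3 and a 1.2-fold lower number (0.08 log units; within the scatter) from compound 1 to compound 4, 1.3-fold (0.10 log units) apart, within the scatter of two such steps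

What the compounds shown leave open is whether an amine or a carboxylic acid in place of the hydroxy would stay within the scatter as well. Also open, from the compounds shown here alone, is whether a shorter chain, such as 2-hydroxyethyl, or a longer chain would do the same.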